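A few compounds are considered here, and "the series" means these few. Any claim that something is new, unique, unknown or untested is made for them only; others in the source may bear on it.

Four acids built on a sulfonyl-linked core are compared here. Compound 1 `O=C(O)CS(=O)(=O)c1ccc(OCc2cccc(-c3ccccc3)c2)cc1` and compound 2 `O=C(O)CS(=O)(=O)c1ccc(OCc2cccc(-c3ccccc3F)c2)cc1` share one core; compound 3 `Cc1nc(-c2ccccc2)sc1COc1ccc(S(=O)(=O)CC(=O)O)cc1` and compound 4 `Cc1nc(-c2ccccc2F)sc1COc1ccc(S(=O)(=O)CC(=O)O)cc1` share another, and the difference between the two cores is not broken down here. In a functional assay on CHO cells for agonist activity at Free fatty acid receptor 1 (Homo sapiens), read by FLIPR and calcium flux (on this read-out higher numbers stand for an effect only at larger amounts of compound and lower numbers for an effect already at smaller amounts), compound 1 gives 288 nM. Compound 2 differs from compound 1 by fluoro in place of hydrogen on an aromatic carbon, and in this assay compound 2 gives 257 nM, which amounts to a 1.1-fold lower number from compound 1 to compound 2 (0.05 log units; within the scatter). In this assay compound 3 gives 331 nM, a number that sits within the scatter of the numbers of compound 1 and compound 2. Compound 4 differs from compound 3 by fluoro in place of hydrogen on an aromatic carbon, the same change as that from compound 1 to compound 2, at a place described in the same words. Compound 4 is therefore expected to show a 1.1-fold lower number from compound 3 to compound 4 (0.04 log units; within the scatter). For the measured compounds named here, that expectation rests only on the single earlier step, which stayed within the scatter, so a step of about that size seems the most likely outcome. For compound 4 the estimate in this assay is 300 nM, with a range from 150 nM to 600 nM.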

Compound 4, half-maximal effective concentration: 550 nM
Estimate against measurement, compound 4: 1.8-fold (0.26 log units) below, and the stated range covers the measured number.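

In this assay, the change from phenyl to 2-fluorophenyl on the second core gives a 1.7-fold higher number from compound 3 to compound 4 (0.22 log units; within the scatter). Set beside the same change on the first core, the two steps cannot be told apart: the same change on two cores in this assay, a 1.1-fold lower number (0.05 log units; within the scatter) from compound 1 to compound 2 and a 1.7-fold higher number (0.22 log units; within the scatter) from compound 3 to compound 4, 1.9-fold (0.27 log units) apart, within the scatter of two such steps. For the compounds shown here, this shows that, on each core, fluoro in place of hydrogen left the number within the usual scatter, and that nothing here points to the core altering what the change does; it does not prove that the change carries over identically, since each core offers only one pair and steps this small could hide a real but modest difference.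

The compounds shown carry only hydrogen or fluoro at this place, so it remains open whether chloro, methoxy or a nitrile there would move the number beyond the scatter on either core. On these data alone, it is also open whether the steps would still match if an amide took the place of the carboxylic acid.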